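Trifluoromethoxy in Place of Trifluoromethyl: Cytotoxicity Outlook

A few compounds are considered here, and "the series" means these few. Any claim that something is new, unique, unknown or untested is made for them only; others in the source may bear on it.

Of the compounds shown here, three built on one shared core have been tested in an ADME assay on A549 cells (Homo sapiens) for cytotoxicity, read by CellTiter-Glo; on this read-out lower numbers stand for higher toxicity in this test and higher numbers for lower toxicity in this test. Compound 1 `Cc1c(Cc2ccc(F)cc2F)c(=O)oc2cc(OCC(O)CN3CCC(C(N)=O)CC3)ccc12` sits at a limit of this assay, reported as > 100000 nM. Compound 2 `Cc1c(Cc2ccc(C(F)(F)F)cc2)c(=O)oc2cc(OCC(O)CN3CCC(C(N)=O)CC3)ccc12` gives 89300 nM in this assay. Compound 3 `Cc1c(Cc2ccccc2C(F)(F)F)c(=O)oc2cc(OCC(O)CN3CCC(C(N)=O)CC3)ccc12` also sits at a limit of this assay, reported as > 100000 nM. The step of an at least 1.1-fold lower number from compound 1 to compound 2 (0.04 log units; that floor lies within the scatter) and the step of an at least 1.1-fold higher number from compound 2 to compound 3 (0.04 log units; that floor lies within the scatter) both stay within the scatter, and the step that the two limits leave unreadable from compound 1 to compound 3 cannot be read because the limit of > 100000 nM in this assay, at which 2 of the 3 values shown sit, holds both of its ends.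

Compound 4 `Cc1c(Cc2ccc(OC(F)(F)F)cc2)c(=O)oc2cc(OCC(O)CN3CCC(C(N)=O)CC3)ccc12` differs from compound 3 by 4-(trifluoromethoxy)phenyl in place of 2-(trifluoromethyl)phenyl on a saturated chain carbon bound to an aromatic carbon. Every measured step here exchanges one substituted phenyl for another in the same place, and none of them moves the number beyond the scatter. The change to compound 4 is therefore expected to behave the same way, so the expected step of a number no higher from compound 3 to compound 4 (the limit leaves the size open) is estimated to stay within the scatter. Compound 4 is expected to give 100000 nM in this assay, with a likely range from 60000 nM to 200000 nM.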

Compound 4, half-maximal cytotoxic concentration: 68200 nM
Compound 4: middle estimate off by 1.5-fold (0.17 log units), on the high side, within the range that was stated.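

In this assay, for the compounds shown here, compound 4 gives the first step on this aromatic carbon with a measured number at both ends, and trifluoromethoxy in place of trifluoromethyl gives a 1.3-fold lower number from compound 2 to compound 4 (0.12 log units; within the scatter). The added oxygen, counted as one hydrogen-bond acceptor, therefore brings no change beyond the scatter in this pair. The comparisons with the other two compounds give only floors, an at least 1.4-fold lower number from compound 3 to compound 4 (0.16 log units; that floor lies within the scatter) and an at least 1.4-fold lower number from compound 1 to compound 4 (0.16 log units; that floor lies within the scatter), and their true size stays unreadable because of this limit: the limit of > 100000 nM in this assay, at which 2 of the 4 values shown sit.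

On these data alone, all four compounds carry a fluorinated phenyl on the saturated chain carbon, so it remains open whether a phenyl bearing an amine or a carboxylic acid would move the number beyond the scatter. As far as these compounds go, it also remains open whether a longer chain between that ring and the shared core would do so.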